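A pyridinylmethyl ester after three esters at the limit

The source may hold more compounds than are shown below. What is called first, only, known or untested is meant among the compounds shown, and "the series" means these compounds.

Three esters of one shared core have been measured in an ADME assay on MCF7 cells (Homo sapiens) for cytotoxicity, read by CellTiter-Glo, with a stated time of 24 h; on this read-out lower numbers stand for stronger inhibition of growth and higher numbers for weaker inhibition of growth. Compound 1 `CC1=C(C(=O)OCc2ccccc2)C(c2ccc(Cl)cc2Cl)NC(=O)N1CCCC(=O)OCc1ccccc1F` gives only a limit of the assay, > 100000 nM. Compound 2 `CC1=C(C(=O)OCc2ccccc2)C(c2ccc(Cl)cc2Cl)NC(=O)N1CCCC(=O)OCC1CC1` likewise gives a limit, > 100000 nM. Compound 3 `COCCOC(=O)CCCN1C(=O)NC(c2ccc(Cl)cc2Cl)C(C(=O)OCc2ccccc2)=C1C` also gives a limit, > 100000 nM; it therefore stands level with the other two, all three sitting at the limit of > 100000 nM in this assay, at which 3 of the 3 values shown sit. The step that the two limits leave unreadable from compound 1 to compound 2 cannot be read, nor can a step that the two limits leave unreadable from compound 1 to compound 3 or a step that the two limits leave unreadable from compound 2 to compound 3.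

Compound 4 `CC1=C(C(=O)OCc2ccccc2)C(c2ccc(Cl)cc2Cl)NC(=O)N1CCCC(=O)OCc1ccccn1` is not yet measured. It differs from compound 3 by pyridin-2-yl in place of methoxymethyl on a saturated chain carbon bound to an oxygen next to a carbonyl group. The three measured steps all change the same ester substituent, and none of them produced a number in this assay, so they bear on the change to compound 4 only as a run of limits whose size cannot be read. The expected step that the limit leaves unreadable from compound 3 to compound 4 is therefore no more than a guess resting on those limits. On that basis compound 4 is expected to give about 150000 nM, within a range from 50000 nM to 500000 nM, and most likely to come back as a limit again.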

Compound 4, concentration for 50% growth inhibition: > 100000 nM
Compound 4 gave a limit, no number (the forecaster's own chance of this, stated with the estimate: 85%); the middle value does not contradict the limit.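

Compound 4 joins compound 1, compound 2 and compound 3 in this assay, so the steps from each of them to compound 4 cannot be read: the limit of > 100000 nM in this assay, at which 4 of the 4 values shown sit. The compounds shown leave open how these four esters rank against one another, and whether any change to this ester substituent would give a measurable value rather than a limit.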